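This account rests on a few compounds, and the source may have more. Where it says the series, first, only, none or still open, it means among the compounds named here.

Measured in a toxicity assay on MT4 cells (Homo sapiens) for cytotoxicity, read by MTT assay, with a stated time of 5 days; on this read-out higher numbers stand for lower toxicity in this test and lower numbers for higher toxicity in this test:
- Compound 1 `Cc1cnc(Nc2ccc(C#N)cc2)nc1Nc1c(F)cc(-c2ccco2)cc1F` gives 8100 nM
- Compound 2 `Cc1cnc(Nc2ccc(C#N)cc2)nc1Nc1c(F)cc(-c2cc(F)nc(F)c2)cc1F` gives 103000 nM
- Compound 3 `Cc1cc(-c2cncnc2)cc(C)c1Nc1ccnc(Nc2ccc(C#N)cc2)n1` gives 6800 nM

Compound 3 and compound 1 lie within the scatter of each other, and compound 2 stands far higher than both. Compound 4 `Cc1ccc(-c2cc(C)c(Nc3ccnc(Nc4ccc(C#N)cc4)n3)c(C)c2)s1` departs from compound 3 by one group: 5-methylthiophen-2-yl in place of pyrimidin-5-yl on an aromatic carbon that is, 5-methylthiophen-2-yl in place of pyrimidin-5-yl on an aromatic carbon. Among the compounds with values here, only one measured step bears on this, and loosely: a 13-fold higher number from compound 1 to compound 2 (1.10 log units; beyond the scatter) when 2,6-difluoropyridin-4-yl replaced furan-2-yl. That large step does not clearly carry over, since compound 3 with a six-membered ring gives 6800 nM and compound 1 with a five-membered ring gives 8100 nM on a differing core. No measurement covers a methylthiophene group. In this assay no step beyond the scatter is therefore expected. The estimate means a 1.2-fold lower number from compound 3 to compound 4 (0.09 log units; within the scatter) and so stays small. Compound 4 is estimated at 5500 nM within a range of 2000 nM to 20000 nM for now.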

Compound 4, half-maximal cytotoxic concentration: 28000 nM
Beside the measured number, compound 4's estimate is 5.1-fold (0.71 log units) below it, outside the stated range (above it).
By their numbers in this assay, from the lowest: compounds 3 and 1 (each within the scatter of the next); then compound 4; then compound 2.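

In this assay, pyrimidin-5-yl giving way to 5-methylthiophen-2-yl produces a 4.1-fold higher number from compound 3 to compound 4 (0.61 log units; beyond the scatter), so this position, para to a large group and meta to two methyl groups, is sensitive to the ring it carries. Within the data shown here, the shift is toward lower toxicity in this test and comes with a five-membered aromatic ring replacing a six-membered one; the only earlier step, a 13-fold higher number from compound 1 to compound 2 (1.10 log units; beyond the scatter), ran in the same numerical direction but with a six-membered ring replacing a five-membered one, on a different core, so ring size alone does not order the two steps. Nothing measured here accounts for the new step.

The compounds shown leave open whether the step belongs to the thiophene ring or to its methyl group, which a plain thiophen-2-yl would separate. As far as these compounds go, how a morpholine at this position would read in this assay also stays open.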